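Ortho Chloro Addition in an Aryl Ether Sulfonylacetic Acid Series

The source may report more compounds than this note shows. Statements on the series, on what has been measured and on what is new or still open speak of the compounds shown alone.

Measured so far:
compound 1 `N#Cc1ccccc1-c1cccc(COc2ccc(S(=O)(=O)CC(=O)O)cc2)c1` 457 nM
compound 2 `Cc1noc(C)c1-c1cccc(COc2ccc(S(=O)(=O)CC(=O)O)cc2)c1` 269 nM

In a functional assay on CHO cells for agonist activity at Free fatty acid receptor 1 (Homo sapiens), read by FLIPR and calcium flux (a higher number here means that more compound is needed for the effect, a lower number that less compound is needed), compound 1 gives 457 nM and compound 2 gives 269 nM. Compound 2 holds the lowest of the two numbers; its nearest neighbour is compound 1, and the step of a 1.7-fold lower number from compound 1 to compound 2 (0.23 log units; within the scatter) lies within the scatter, so the two compounds cannot be ordered.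

Compound 3 `Cc1noc(C)c1-c1cc(COc2ccc(S(=O)(=O)CC(=O)O)cc2)ccc1Cl` differs from compound 2 by chloro in place of hydrogen on an aromatic carbon. Among the compounds with values here, no measured step bears directly on this change: the single step in hand exchanges the aryl partner and leaves the ring hydrogens untouched, and that step itself stayed within the scatter. Without a related precedent, the step from compound 2 to compound 3 is expected to be small, a 1.1-fold lower number from compound 2 to compound 3 (0.03 log units; within the scatter), no larger than the scatter. Compound 3 is therefore estimated at 250 nM in this assay, with a range from 90 nM to 700 nM.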

Compound 3, half-maximal effective concentration: 214 nM
The estimate for compound 3 lay 1.2-fold (0.07 log units) above the measured number; the measured number falls inside the stated range.
By their numbers in this assay, from the lowest: compounds 3, 2 and 1 (each within the scatter of the next, the first and the last beyond it).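

Chloro in place of hydrogen, on the aromatic carbon ortho to the 3,5-dimethyl-1,2-oxazol-4-yl group and para to a large group, gives in this assay a 1.3-fold lower number from compound 2 to compound 3 (0.10 log units; within the scatter). Within the data shown here, the earlier step changed only the aryl partner, so this is the first reading on a substituent at this position of the six-membered aromatic ring: the position accepts a chlorine atom with no change that can be told from the scatter. Nothing at hand gives a reason for this outcome.

Open, from the compounds shown here alone, is whether a different group at this position, such as fluoro, methoxy or an amine, would give a step beyond the scatter. Also open, going by these compounds, is whether chloro gives a similar step with the 2-cyanophenyl partner of compound 1.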